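This account rests on a few compounds, and the source may have more. Where it says the series, first, only, none or still open, it means among the compounds named here.

Measured compounds in a functional assay on PANC-1 cells (Homo sapiens) for inhibition, read by MTT assay, with a stated time of 72 h; on this read-out lower numbers stand for stronger inhibition of growth and higher numbers for weaker inhibition of growth:
compound 1 `O=S(=O)(NCCCNCc1cccc2ccccc12)c1cc(C(F)(F)F)cc(C(F)(F)F)c1` gives 2700 nM
compound 2 `O=S(=O)(NCCCNCC1COc2ccccc2O1)c1cc(C(F)(F)F)cc(C(F)(F)F)c1` gives 3400 nM
compound 3 `O=S(=O)(NCCCNCc1ccc(Br)cc1)c1cc(C(F)(F)F)cc(C(F)(F)F)c1` gives 2200 nM

All three share the same core and differ only in the group on a saturated chain carbon bound to an amine nitrogen. Compound 3 has the lowest of the three numbers in this assay, but its separation from the others is small: a 1.2-fold lower number from compound 1 to compound 3 (0.09 log units; within the scatter) and a 1.5-fold lower number from compound 2 to compound 3 (0.19 log units; within the scatter), both within the scatter, so no ordering among compounds 1, 2 and 3 can be claimed.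

Compound 4 `O=S(=O)(NCCCNCc1ccc(Cl)c(Cl)c1)c1cc(C(F)(F)F)cc(C(F)(F)F)c1` is not yet measured. It differs from compound 3 as follows: 3,4-dichlorophenyl in place of 4-bromophenyl on a saturated chain carbon bound to an amine nitrogen

Within the data shown here, the steps that bear on this change are those that swap the group at the same place: a 1.2-fold lower number from compound 1 to compound 3 (0.09 log units; within the scatter), a 1.5-fold lower number from compound 2 to compound 3 (0.19 log units; within the scatter) and a 1.3-fold higher number from compound 1 to compound 2 (0.10 log units; within the scatter). Each lies within the scatter, although the groups exchanged there are of quite different kind, from naphthalen-1-yl to 2,3-dihydro-1,4-benzodioxin-2-yl to 4-bromophenyl. Going from 4-bromophenyl to 3,4-dichlorophenyl is a smaller change than any of those. The expectation is therefore a step in this assay of no size beyond the scatter, estimated as no change at the digits printed from compound 3 to compound 4 (within the scatter). For compound 4 the estimate in this assay is 2200 nM, with a range from 1000 nM to 4800 nM.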

Compound 4, concentration for 50% growth inhibition: 5600 nM
Beside the measured number, compound 4's estimate is 2.5-fold (0.41 log units) below it; the measured number lies above the stated range.
By their numbers in this assay, from the lowest: compounds 3, 1, 2 and 4 (each within the scatter of the next, the first and the last beyond it).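

In this assay the position on a saturated chain carbon bound to an amine nitrogen no longer looks indifferent to the group it carries: 3,4-dichlorophenyl in place of 4-bromophenyl gives the step (a 2.5-fold higher number from compound 3 to compound 4 (0.41 log units; beyond the scatter)), and 3,4-dichlorophenyl in place of naphthalen-1-yl gives the step (a 2.1-fold higher number from compound 1 to compound 4 (0.32 log units; beyond the scatter)), the first two at this place beyond the scatter, both modest. The exchange for 2,3-dihydro-1,4-benzodioxin-2-yl stays small (a 1.6-fold higher number from compound 2 to compound 4 (0.22 log units; within the scatter)), so compound 4 is set apart from compounds 1 and 3 only, not from compound 2. The largest step shown here joins two groups that both hold one six-membered aromatic ring of carbon only and differ in their halogens, so a close match in ring type does not ensure a matching number, and nothing available here accounts for that step.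

The compounds shown do not separate the effect of the added chlorine from that of chlorine standing in place of bromine, which 4-chlorophenyl would address directly. Also open, as far as these compounds go, is whether a non-halogen group such as 4-methoxyphenyl, or a longer chain between the two nitrogens, would move the number at all.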